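Formyl to Fluoro on the Phenyl Ring: Expected Inhibition

A few compounds are considered here, and "the series" means these few. Any claim that something is new, unique, unknown or untested is made for them only; others in the source may bear on it.

Measured compounds:
compound 1 `c1ccc(-c2cn3ccnc3c(-c3ccc4ncn(C5CCCCC5)c4c3)n2)cc1` gives 28.8%
compound 2 `COc1ccc(-c2cn3ccnc3c(-c3ccc4ncn(C5CCCCC5)c4c3)n2)cc1` gives 63.6%
compound 3 `O=Cc1ccc(-c2cn3ccnc3c(-c3ccc4ncn(C5CCCCC5)c4c3)n2)cc1` gives 20.7%

All three were tested in a functional assay on SN12C cells (Homo sapiens) for inhibition, read by sulforhodamine B assay, with a stated time of 48 h, tested at 10 uM; a lower number here means less inhibition, a higher number more inhibition at the concentration tested (going by the name of the read-out). Compound 3 stands lowest of the three numbers, nearest to compound 1 and furthest from compound 2. The change from compound 3 to compound 4 `Fc1ccc(-c2cn3ccnc3c(-c3ccc4ncn(C5CCCCC5)c4c3)n2)cc1` is fluoro in place of formyl on an aromatic carbon. Going by the values given here, two measured steps bear on it: a number 8.1 percentage points lower from compound 1 to compound 3 (within the scatter), and a number 42.9 percentage points lower from compound 2 to compound 3 (beyond the scatter). Among the compounds with values here, no measured step brings fluoro in, so the closest guide is that compound 1, bearing hydrogen at this position, and compound 3 lie within the scatter of each other. Compound 4 is therefore expected to stay close to compound 3, with no step beyond the scatter: a number 7.3 percentage points higher from compound 3 to compound 4 (within the scatter). Compound 4 is estimated at 28%, within 10% to 50%.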

Compound 4, a percentage reported as inhibition, at one concentration (the size of the read-out at that concentration, not a potency): 3.97%
For compound 4 the middle estimate is 24 percentage points above the measured one, and the stated range ends above it.
By their numbers in this assay, from the lowest: compound 4; then compounds 3 and 1 (each within the scatter of the next); then compound 2.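

In this assay, fluoro in place of hydrogen gives a number 24.8 percentage points lower from compound 1 to compound 4 (beyond the scatter), whereas formyl stayed within the scatter of hydrogen, so this position can lose inhibition as well as gain it. Fluoro also separates from formyl, with a number 16.7 percentage points lower from compound 3 to compound 4 (beyond the scatter), and from methoxy, with a number 59.6 percentage points lower from compound 2 to compound 4 (beyond the scatter). Among the groups shown at this place, methoxy alone now stands clearly above hydrogen and fluoro alone clearly below it.

Nothing available explains why these groups differ. On these data alone, how an amine or a carboxylic acid at this place would compare remains open.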